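Swapping the aryl group on the triazole nitrogen

This account rests on a few compounds, and the source may have more. Where it says the series, first, only, none or still open, it means among the compounds named here.

Measured so far:
- compound 1, `Cc1ccccc1-n1cc(-c2ccccc2NS(=O)(=O)c2c[nH]c(=O)[nH]c2=O)nn1`, giving 9570 nM
- compound 2, `Cc1cccc(-n2cc(-c3cccc(NS(=O)(=O)c4c[nH]c(=O)[nH]c4=O)c3)nn2)c1`, giving 9100 nM

The two measured compounds share one core, a sulfonamide joined to a triazole that carries an aryl group on one of its ring nitrogens. Both were tested in a functional assay on SGC-7901 cells (Homo sapiens) for antiproliferative activity, read by MTT assay, with a stated time of 24 h; a higher number here means a weaker inhibitor, a lower number a stronger inhibitor. In this assay compound 1 gives 9570 nM, and compound 2 gives 9100 nM. Compound 2 has the lowest of the two numbers, but its gap to compound 1 is within the scatter of repeated measurements, so the two cannot be told apart on these data.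

Compound 3, `O=c1[nH]cc(S(=O)(=O)Nc2cccc(-c3cn(-c4ccc(F)cc4)nn3)c2)c(=O)[nH]1`, is not yet measured. It differs from compound 2 in one place: 4-fluorophenyl in place of 3-methylphenyl on an aromatic nitrogen. For the measured compounds named here, no measured pair shows the effect of such a swap, so there is no step from which to read a direction. Both measured compounds sit close together, and nothing here points to a change beyond the scatter. Compound 3 is therefore expected to stay close to compound 2, with an estimated step of a 1.0-fold lower number from compound 2 to compound 3 (0.00 log units; within the scatter). The estimated value of compound 3 in this assay is 9000 nM, expected between 3000 nM and 27000 nM.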

Compound 3, half-maximal inhibitory concentration: > 20000 nM
Compound 3: only a limit was reported (the forecaster's own chance of this, stated with the estimate: 15%); middle value at least 2.2-fold (0.34 log units) from the limit.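

In this assay, for the compounds shown here, 4-fluorophenyl in place of 3-methylphenyl on an aromatic nitrogen gives an at least 2.1-fold higher number from compound 2 to compound 3 (0.34 log units; beyond the scatter), the first step in these data that can be read at all. This position is therefore not indifferent to the aryl group it carries: the two groups match in heavy-atom count, each has one six-membered aromatic ring of carbon only, and neither has hydrogen-bond donors or acceptors, yet the two compounds can be told apart. The value of compound 3 is a limit and not a number, so the step sets only a lower bound on the size of the change and leaves its true size unknown: the limit of > 20000 nM in this assay, at which 1 of the 3 values shown sits.

The swap alters two things at once, the substituent itself (methyl to fluorine) and where it stands on the phenyl ring, and these compounds cannot separate the two. From the compounds shown here alone, whether a 4-methylphenyl or a 3-fluorophenyl group on the same nitrogen would stay near compound 2 or fall with compound 3 remains open, as does the effect of an unsubstituted phenyl group.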